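Removing the Whole Side Chain to Leave a Free Amine

The compounds below may be only part of what the source reports. "The series", "measured", "known", "first", "only" and "open" are said of these compounds alone.

Of the compounds shown here, three sharing one core have been measured in an ADME assay on L6 cells (Rattus norvegicus) for cytotoxicity, read by resazurin assay, with a stated time of 72 h; on this read-out lower numbers stand for stronger inhibition and higher numbers for weaker inhibition. Compound 1 `CN1CCN(CC(=O)OC2CC3(N4CCCCC4)CC(c4ccccc4)C2C(c2ccccc2)C3)CC1` gives 29500 nM. Compound 2 `CN1CCN(CC(=O)NC2CC3(N4CCCCC4)CC(c4ccccc4)C2C(c2ccccc2)C3)CC1` gives 57500 nM, a change of a 1.9-fold higher number from compound 1 to compound 2 (0.29 log units; within the scatter). Compound 3 `O=C(CN1CCCCC1)OC1CC2(N3CCCCC3)CC(c3ccccc3)C1C(c1ccccc1)C2` gives 60400 nM; its number sits within the scatter of compound 2, the gap being a 1.1-fold higher number from compound 2 to compound 3 (0.02 log units; within the scatter), and apart only from compound 1, by a 2.0-fold higher number from compound 1 to compound 3 (0.31 log units; beyond the scatter). Compound 4 `NC1CC2(N3CCCCC3)CC(c3ccccc3)C1C(c1ccccc1)C2` has not yet been measured. The change is amino in place of (((piperidin-1-yl)methyl)carbonyl)oxy on a saturated ring carbon. Within the data shown here, no measured step removes the side chain entirely; the two steps that alter it, a 2.0-fold higher number from compound 1 to compound 3 (0.31 log units; beyond the scatter) and a 1.9-fold higher number from compound 1 to compound 2 (0.29 log units; within the scatter), were small. Compound 4 is therefore expected to shift only slightly, by a 1.0-fold lower number from compound 3 to compound 4 (0.00 log units; within the scatter), in this assay. The estimate for compound 4 is 60000 nM, with a range from 25000 nM to 150000 nM.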

Compound 4, half-maximal inhibitory concentration: 35000 nM
Estimate against measurement, compound 4: 1.7-fold (0.23 log units) above; low and high end bracket the measured number.
By their numbers in this assay, from the lowest: compounds 1, 4, 2 and 3 (each within the scatter of the next, the first and the last beyond it).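

Cutting the side chain down to a bare amino group on this saturated ring carbon keeps the number in this assay within the scatter of all three compounds that carry a side chain: a 1.7-fold lower number from compound 3 to compound 4 (0.24 log units; within the scatter), a 1.6-fold lower number from compound 2 to compound 4 (0.22 log units; within the scatter) and a 1.2-fold higher number from compound 1 to compound 4 (0.07 log units; within the scatter). Among these compounds, then, a full side chain at this position is not needed for a number in this range. No measurement here explains why the side chain matters so little. As far as these compounds go, whether a hydroxyl group or a dimethylamino group on this carbon would move the number beyond the scatter stays open, as does the effect of replacing the piperidin-1-yl group elsewhere on the shared core.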